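Swapping the methylphenyl back for a chloropyridyl

The source may hold more compounds than are shown below. What is called first, only, known or untested is meant among the compounds shown, and "the series" means these compounds.

For the measured compounds named here, compound 2 `Cc1cccc(S(=O)(=O)N2CCC(N3CCC(C)CC3)CC2)c1` holds the only numerical value in a functional assay on DLD-1 cells (Homo sapiens) for antiproliferative activity, read by CellTiter-Glo, with a stated time of 72 h (a higher number here means a weaker inhibitor, a lower number a stronger inhibitor), giving 25 nM. Compound 1 `CC1CCN(C2CCN(S(=O)(=O)c3cccnc3Cl)CC2)CC1` reaches only a limit in this assay, > 5000 nM. Going by the values given here, the single measured step, an at least 200-fold lower number from compound 1 to compound 2 (2.30 log units; beyond the scatter), is large. Among the compounds with values here, compound 3 `CC1CCN(C2CCN(S(=O)(=O)c3ccc(Cl)nc3)CC2)CC1` carries 6-chloropyridin-3-yl in place of 3-methylphenyl on a sulfonyl sulfur, bringing in 6-chloropyridin-3-yl rather than the 2-chloropyridin-3-yl of compound 1, so the one relevant step runs the other way and is bounded by the limit of > 5000 nM in this assay, at which 1 of the 2 values shown sits. A large rise is therefore expected, a 60-fold higher number from compound 2 to compound 3 (1.78 log units; beyond the scatter), though the other chloropyridin-3-yl may not repeat it fully. Compound 3 is estimated at 1500 nM, between 150 nM and 10000 nM.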

Compound 3, half-maximal inhibitory concentration: 3700 nM
Compound 3: the middle estimate sits 2.5-fold (0.39 log units) below what was measured; the range from low to high includes it.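

In this assay, the loss is not confined to the 2-chloropyridin-3-yl group: the 6-chloropyridin-3-yl group on the sulfonyl sulfur also gives a 150-fold higher number from compound 2 to compound 3 (2.17 log units; beyond the scatter). The two chloropyridinyl groups cannot be ranked, with an at least 1.3-fold lower number from compound 1 to compound 3 (0.13 log units; that floor lies within the scatter), because the value of compound 1 is a limit and not a number: the limit of > 5000 nM in this assay, at which 1 of the 3 values shown sits.

Whether the ring nitrogen, the chlorine or both account for the loss stays open. So does how a plain pyridin-3-yl or a 3-chlorophenyl group on the sulfonyl sulfur would compare.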